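The source may report more compounds than this note shows. Statements on the series, on what has been measured and on what is new or still open speak of the compounds shown alone.

In a functional assay (QGY7701 cells, Homo sapiens) for inhibition, read by MTT assay, with a stated time of 48 h (on this read-out lower numbers stand for stronger inhibition and higher numbers for weaker inhibition), compound 2 `COc1ccc2c(=O)c(/C=C/C(=O)Nc3cccc(Cl)c3)coc2c1` gives only a limit, > 100000 nM, not a number. Compound 1 `COc1ccc2c(=O)c(/C=C/C(=O)Nc3cccc(C)c3)coc2c1` likewise reaches only a limit in this assay, > 100000 nM. Compound 3 `COc1ccc2c(=O)c(/C=C/C(=O)NCc3ccc(F)cc3)coc2c1` gives 7960 nM in this assay. The step from compound 1 to compound 2 is a step that the two limits leave unreadable from compound 1 to compound 2. The steps of an at least 12-fold lower number from compound 1 to compound 3 (1.09 log units; beyond the scatter) and an at least 12-fold lower number from compound 2 to compound 3 (1.09 log units; beyond the scatter) are large, yet both exchange a substituted phenyl on the amide-type nitrogen for 4-fluorobenzyl, whereas compound 4 `COc1ccc2c(=O)c(/C=C/C(=O)Nc3ccc(F)cc3)coc2c1` keeps a phenyl there: 4-fluorophenyl in place of 3-chlorophenyl on an amide-type nitrogen. Two of the three values sit at the limit (the limit of > 100000 nM in this assay, at which 2 of the 3 values shown sit), and no readable step exists between two such phenyl amides. Compound 4 is therefore expected to remain near that limit, the expected step being a step that the limit leaves unreadable from compound 2 to compound 4. The estimate for compound 4 is 150000 nM, between 30000 nM and 800000 nM.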

Compound 4, half-maximal inhibitory concentration: > 100000 nM
Compound 4: a limit, no number; the forecaster's own chance of this, stated with the estimate: 75%; the middle value lies beyond the limit too.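

Compound 4 gives only a limit in this assay, > 100000 nM, not a number. The fluorine is kept on both sides when 4-fluorophenyl replaces 4-fluorobenzyl on the amide-type nitrogen, and this gives an at least 12-fold higher number from compound 3 to compound 4 (1.09 log units; beyond the scatter), so the large gap to compound 3 no longer rests only on comparisons that also change the ring substituent. The steps among compound 1, compound 2 and compound 4 cannot be read, and the phenyl amides all stand at one limit: the limit of > 100000 nM in this assay, at which 3 of the 4 values shown sit.

Compound 3 is the only benzyl amide shown. On these data alone, whether plain benzyl or a 2-phenylethyl chain on the amide-type nitrogen also gives a readable number stays open.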